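The compounds below may be only part of what the source reports. "The series", "measured", "known", "first", "only" and "open" are said of these compounds alone.

Of the compounds shown here, two have been measured in an assay on THP-1 cells for displacement of a labelled ligand from C-C chemokine receptor type 1 (Homo sapiens); on this read-out lower numbers stand for stronger inhibition and higher numbers for weaker inhibition. Compound 2 `CC(C)C(NC(=O)Oc1ccccc1)C(=O)N1CCC(c2ccc(Cl)cc2)CC1` gives 265 nM in this assay, and compound 1 `CC(C)C(NS(=O)(=O)Cc1ccccc1)C(=O)N1CCC(c2ccc(Cl)cc2)CC1` gives 303 nM. Between them lies a 1.1-fold lower number from compound 1 to compound 2 (0.06 log units; within the scatter), so the two cannot be told apart, and compound 2 stands level with compound 1 rather than ahead of it.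

Compound 3 `CC(C)C(NC(=O)OCc1ccccc1)C(=O)N1CCC(c2ccc(Cl)cc2)CC1` is the next compound in the series. It differs from compound 2 in one place: benzyl in place of phenyl on an oxygen next to a carbonyl group. For the measured compounds named here, only one measured step exists, from compound 1 to compound 2, and it changed a different part of the molecule, the group on the amine nitrogen; it stayed within the scatter. Going by the values given here, no measured step bears directly on swapping phenyl for benzyl on that oxygen. With nothing pointing in either direction, the expected step is a 1.0-fold lower number from compound 2 to compound 3 (0.01 log units; within the scatter), meaning no change beyond the scatter. On that basis compound 3 is estimated to give 260 nM in this assay, with a range from 100 nM to 700 nM.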

Compound 3, half-maximal inhibitory concentration: 1080 nM
Compound 3: the middle estimate sits 4.2-fold (0.62 log units) below what was measured; the whole stated range lies below it.
By their numbers in this assay, from the lowest: compounds 2 and 1 (each within the scatter of the next); then compound 3.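

This position is less forgiving than the first step suggested. In this assay, benzyl in place of phenyl on the oxygen gives a 4.1-fold higher number from compound 2 to compound 3 (0.61 log units; beyond the scatter) and so weaker inhibition, even though both groups carry one six-membered aromatic ring of carbon only and neither has a hydrogen-bond donor or acceptor. The group on the amine nitrogen therefore cannot be exchanged freely, as benzyloxycarbonyl in place of benzylsulfonyl gives a 3.6-fold higher number from compound 1 to compound 3 (0.55 log units; beyond the scatter) and also weakens inhibition. Nothing available explains why the benzyl group has this effect.

From the compounds shown here alone, it remains open whether a longer chain, such as phenylethyl, on that oxygen would weaken inhibition further or whether the loss is particular to benzyl. The effect of a methoxy group on the phenyl ring of compound 2 is also unknown.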